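The compounds below may be only part of what the source reports. "The series", "measured", "known", "first", "only" and "open" are said of these compounds alone.

Compound 2 `CC(C)COc1ccccc1C1CC(=O)c2ccccc2O1` has been measured in a functional assay on J774.A1 cells (Mus musculus) for inhibition, read by Griess assay, with stated times of 1 h and 24 h (a higher number here means a weaker inhibitor, a lower number a stronger inhibitor), where compound 2 gives 33200 nM. Among the measured compounds shown here, only one other number is available: compound 1 `CC(C)c1ccc(COc2ccccc2C2CC(=O)c3ccccc3O2)cc1`, which in this assay gives 28600 nM, and the two values lie within the scatter of each other, so neither can be called the stronger inhibitor. Compound 3 `COCOc1ccccc1C1CC(=O)c2ccccc2O1` differs from compound 2 in a single place: methoxy in place of isopropyl on a saturated chain carbon bound to an oxygen on an aromatic ring. For the measured compounds named here, the one measured step that touches this same place is a 1.2-fold higher number from compound 1 to compound 2 (0.06 log units; within the scatter), in which a different exchange on that saturated chain carbon left the number unmoved beyond the scatter. On that basis the step from compound 2 to compound 3 is expected to be a 1.1-fold higher number from compound 2 to compound 3 (0.02 log units; within the scatter), with no clear direction. Compound 3 is therefore estimated at 35000 nM, with a range from 14000 nM to 85000 nM.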

Compound 3, half-maximal inhibitory concentration: 35200 nM
Beside the measured number, compound 3's estimate is 1.0-fold (0.00 log units) below it; measured number inside the range.
By their numbers in this assay, from the lowest: compounds 1, 2 and 3 (each within the scatter of the next).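

In this assay, putting methoxy in place of isopropyl on this saturated chain carbon gives a 1.1-fold higher number from compound 2 to compound 3 (0.03 log units; within the scatter) and so brings in a hydrogen-bond acceptor without moving the number beyond the scatter. Putting methoxy in place of 4-isopropylphenyl, an exchange that also removes a whole ring, gives a 1.2-fold higher number from compound 1 to compound 3 (0.09 log units; within the scatter) and likewise stays within the scatter, so the three groups at this place cannot be told apart in this assay. No independent measurement here helps to explain this lack of separation.

Going by these compounds, whether an amine or a carboxylic acid at this place would move the number beyond the scatter remains open. So does whether changes elsewhere on the shared core would alter the number more than these exchanges do.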